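This account rests on a few compounds, and the source may have more. Where it says the series, first, only, none or still open, it means among the compounds named here.

Compound 2 `CCC(C)(C)Cc1c[nH]c(CCc2ccc(-c3csnn3)cc2)n1` gives 11 nM in a functional assay on HEK293 cells for agonist activity at Bombesin receptor subtype-3 (Mus musculus), read by luminescence and calcium flux, with a stated time of 10 min (on this read-out lower numbers stand for an effect already at smaller amounts and higher numbers for an effect only at larger amounts of compound), and stands level with compound 1 `CCC(C)(C)Cc1c[nH]c(CCc2ccc(-c3cnccn3)cc2)n1`, which gives 11 nM in this assay. Going by the values given here, the only step so far, no change at the digits printed from compound 1 to compound 2 (within the scatter), left the read-out flat within the scatter. Compound 3 `CCC(C)(C)Cc1c[nH]c(CCc2ccc(-n3cncn3)cc2)n1` differs from compound 2 by 1H-1,2,4-triazol-1-yl in place of 1,2,3-thiadiazol-4-yl on an aromatic carbon. Because that earlier swap of one aromatic ring for another gave no change at the digits printed from compound 1 to compound 2 (within the scatter), no step beyond the scatter is expected here. The expected step from compound 2 to compound 3 is a 1.1-fold higher number from compound 2 to compound 3 (0.04 log units; within the scatter). Compound 3 is therefore estimated at 12 nM, with a range from 4 nM to 40 nM.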

Compound 3, half-maximal effective concentration: 12 nM
Estimate against measurement, compound 3: no gap at the digits printed, and the stated range covers the measured number.
By their numbers in this assay, from the lowest: compounds 1, 2 and 3 (each within the scatter of the next).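

Putting 1H-1,2,4-triazol-1-yl on this aromatic carbon, para to a large group, gives a 1.1-fold higher number from compound 2 to compound 3 (0.04 log units; within the scatter) in this assay and, against pyrazin-2-yl, a 1.1-fold higher number from compound 1 to compound 3 (0.04 log units; within the scatter) on the same read-out. All three aromatic rings therefore read alike here, including one joined through a ring nitrogen rather than a ring carbon. Nothing available explains this flat result. Still open, as far as these compounds go, is whether a group that is not an aromatic ring, such as an amine, a carboxylic acid or a longer chain, would keep the read-out level at this position.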